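Aryl swap at the saturated ring carbon: pyridin-3-yl

The source may hold more compounds than are shown below. What is called first, only, known or untested is meant among the compounds shown, and "the series" means these compounds.

Of the compounds shown here, two have been measured in a functional assay on B16-F10 cells (Mus musculus) for antiproliferative activity, read by MTT assay, with a stated time of 48 h; a lower number here means a stronger inhibitor, a higher number a weaker inhibitor. Compound 1 `COc1ccc(C2OC(c3ccc4ccccc4c3)=NN2C(C)=O)cc1` gives 6.86 ug/mL. Compound 2 `CC(=O)N1N=C(c2ccc3ccccc3c2)OC1c1ccccc1Br` gives 6.98 ug/mL; of the two numbers it is the one on top, yet it sits alongside compound 1, the pair lying within the scatter of each other. Among the compounds with values here, the only step so far, a 1.0-fold higher number from compound 1 to compound 2 (0.01 log units; within the scatter), shows that exchanging one aryl group on the saturated ring carbon for another left the number flat. The unmeasured compound 3 `CC(=O)N1N=C(c2ccc3ccccc3c2)OC1c1cccnc1` keeps the shared core of compound 2 and alters the same position: pyridin-3-yl in place of 2-bromophenyl on a saturated ring carbon. That earlier step is the only one that bears on this change, and it was flat. On that basis no step beyond the scatter is expected in this assay. The expected step is a 1.0-fold higher number from compound 2 to compound 3 (0.00 log units; within the scatter). Compound 3 is therefore estimated at 7 ug/mL in this assay. Its expected range runs from 3.5 ug/mL to 14 ug/mL. With a single flat step behind it, the range is kept broad.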

Compound 3, half-maximal inhibitory concentration: 3.06 ug/mL
Estimate against measurement, compound 3: 2.3-fold (0.36 log units) above, and the stated range ends above it.
By their numbers in this assay, from the lowest: compound 3; then compounds 1 and 2 (each within the scatter of the next).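

In this assay the saturated ring carbon proves not to be indifferent to the aryl group: pyridin-3-yl gives a 2.3-fold lower number from compound 2 to compound 3 (0.36 log units; beyond the scatter) and also a 2.2-fold lower number from compound 1 to compound 3 (0.35 log units; beyond the scatter) while 2-bromophenyl and 4-methoxyphenyl remain within the scatter of each other. Within the data shown here, both steps are modest, but they are the first to lie beyond the scatter, and they come with a six-membered aromatic ring with 1 hetero atom, which replaces a ring of carbon only and also carries no bromine or methoxy group. No measured information bears on the reason for this shift.

The compounds shown leave open whether the ring nitrogen of pyridin-3-yl matters or whether the loss of the bromine or methoxy group is enough, a question that unsubstituted phenyl on the same carbon would help to separate. They also leave open whether the location of that nitrogen counts, which pyridin-2-yl and pyridin-4-yl at this position would test against compound 3.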